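Compound 3 to compound 4: a new group on the carbonyl

This account rests on a few compounds, and the source may have more. Where it says the series, first, only, none or still open, it means among the compounds named here.

Going by the values given here, in an ADME assay on microsomes from liver (Mus musculus) for metabolic stability, with a stated time of 10 min (a higher number here means that more of the compound is left, a lower number that less of the compound is left), compound 1 `C[C@]1(C(=O)O)CC[C@H](C(=O)N2CC[C@](c3ccc(C(F)(C(F)(F)F)C(F)(F)F)cc3)(S(=O)(=O)c3ccc(F)cc3)C2)CC1` gives 93%, the only number available. Compound 2 `CCC[C@]1(C(=O)N2CC[C@](c3ccc(C(F)(C(F)(F)F)C(F)(F)F)cc3)(S(=O)(=O)c3ccc(F)cc3)C2)CC[C@H](C(=O)O)CC1` stands at "not determined" (no result reported). Compound 3 `COC(=O)[C@H]1CC[C@H](C(=O)N2CC[C@](c3ccc(C(F)(C(F)(F)F)C(F)(F)F)cc3)(S(=O)(=O)c3ccc(F)cc3)C2)CC1` also stands at "not determined" (no result reported), so it has no position on this scale. Compound 4 `O=C(N1CC[C@](c2ccc(C(F)(C(F)(F)F)C(F)(F)F)cc2)(S(=O)(=O)c2ccc(F)cc2)C1)C1(F)CCS(=O)(=O)CC1` departs from compound 3 by 4-fluoro-1,1-dioxothian-4-yl in place of 4-(methoxycarbonyl)cyclohexyl on a carbonyl carbon; the entering group, like the one it replaces, carries no net charge. Without a number for compound 3, no step can be read from it in this assay. Among the compounds with values here, the only anchor is compound 1 at 93%, and against that value a difference within the usual scatter, or a modest fall, is expected. For compound 4 the estimated value is 85%, with an expected range of 65% to 100%.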

Compound 4, percent of the compound remaining: 90%
Beside the measured number, compound 4's estimate is 5 percentage points below it; low and high end bracket the measured number.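

In this assay this place on the carbonyl carbon now carries a second number, showing a number 3 percentage points lower from compound 1 to compound 4 (within the scatter) and leaving the two groups unseparated. A 4-fluoro-1,1-dioxothian-4-yl group, with no carboxylic acid, therefore gives a read-out that cannot be told apart from that of the 4-carboxy-4-methylcyclohexyl group. No available evidence bears on the reason for this result.

Steps from compound 2 and compound 3 cannot be read, so the propyl and methyl ester variations remain unplaced. As far as these compounds go, whether an amine on this ring would stay within the scatter also remains open.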